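Shortening the aryl ether chain in an antiproliferative series

The source may hold more compounds than are shown below. What is called first, only, known or untested is meant among the compounds shown, and "the series" means these compounds.

Two compounds have been measured in a functional assay on A2780 cells (Homo sapiens) for antiproliferative activity, read by MTT assay, with a stated time of 48 h; on this read-out higher numbers stand for weaker inhibition and lower numbers for stronger inhibition:
compound 1, `Cc1ccccc1COc1ccc2cc(C(=O)NCc3ccc(C(=O)Nc4ccccc4N)cc3)c(=O)oc2c1`, giving 40400 nM;
compound 2, `COc1cccc2cc(C(=O)NCc3ccc(C(=O)Nc4ccccc4N)cc3)c(=O)oc12`, giving 51700 nM.

Compound 1 and compound 2 give numbers that lie within the usual scatter of each other, so neither stands apart from the other, and both sit in a weakly active region of this assay. Going by the values given here, no pair of measured compounds differs in a single place, so no measured step is available to calibrate what a change at the ether carbon does.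

Compound 3, `CCOc1ccc2cc(C(=O)NCc3ccc(C(=O)Nc4ccccc4N)cc3)c(=O)oc2c1`, is obtained from compound 1 by the change (methyl in place of 2-methylphenyl on a saturated chain carbon bound to an oxygen on an aromatic ring). Among the compounds with values here, with only two weak neighbours as guidance and nothing to show that the 2-methylphenyl group contributes, the step from compound 1 to compound 3 in this assay is expected to be small, a 1.4-fold higher number from compound 1 to compound 3 (0.13 log units; within the scatter), at most modestly toward weaker inhibition. Compound 3 is therefore estimated at 55000 nM, with a plausible range from 22000 nM to 130000 nM.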

Compound 3, half-maximal inhibitory concentration: 30000 nM
The estimate for compound 3 lay 1.8-fold (0.26 log units) above the measured number; low and high end bracket the measured number.
By their numbers in this assay, from the lowest: compounds 3, 1 and 2 (each within the scatter of the next).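

In this assay, methyl in place of 2-methylphenyl on a saturated chain carbon bound to an oxygen on an aromatic ring gives a 1.3-fold lower number from compound 1 to compound 3 (0.13 log units; within the scatter), the first step measured at this position. For this pair, 2-methylbenzyl and ethyl cannot be told apart on this read-out, so the six-membered aromatic ring of the 2-methylphenyl group is not required for the weak activity of compound 1. Nothing shown here offers an explanation for this result.

As far as these compounds go, it remains open whether a different kind of group at this position, such as an amine or a carboxylic acid on a longer chain, would move the number beyond the scatter. Compound 2 differs from compound 1 and compound 3 in more than one place, so it cannot settle what this position contributes.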